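This account rests on a few compounds, and the source may have more. Where it says the series, first, only, none or still open, it means among the compounds named here.

Compound 3 `COc1cc2c(Oc3ccc(NC(=O)c4cn(-c5ccccc5OC(F)(F)F)cn4)cc3F)ccnc2cc1OCCCN1CCCCC1` belongs to a set of three analogues that share one core and differ in the aryl group on the aromatic nitrogen. In a functional assay on HT-29 cells (Homo sapiens) for cytotoxicity, read by MTT assay, with a stated time of 72 h (on this read-out higher numbers stand for weaker inhibition and lower numbers for stronger inhibition), compound 3 gives 250 nM, the second highest of the three numbers. Compound 1 `COc1cc2c(Oc3ccc(NC(=O)c4cn(-c5ccccc5OC)cn4)cc3F)ccnc2cc1OCCCN1CCN(C)CC1` gives 80 nM in this assay, and compound 2 `COc1cc2c(Oc3ccc(NC(=O)c4cn(-c5ccc(Cl)cc5)cn4)cc3F)ccnc2cc1OCCCN1CCN(C)CC1` gives 1350 nM; compound 3 thus stands at a higher number than compound 1 and at a lower number than compound 2, both differences beyond the scatter.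

Compound 4 `COc1cc2c(Oc3ccc(NC(=O)c4cn(-c5ccc(Cl)cc5Cl)cn4)cc3F)ccnc2cc1OCCCN1CCCCC1` carries 2,4-dichlorophenyl in place of 2-(trifluoromethoxy)phenyl on an aromatic nitrogen. Within the data shown here, the one measured step that bears on this change is a 17-fold higher number from compound 1 to compound 2 (1.23 log units; beyond the scatter), where the oxygen-bearing group at the 2-position was lost and a chlorine at the 4-position entered, and the number rose sharply. The change from compound 3 to compound 4 likewise removes the oxygen-bearing 2-substituent and introduces a 4-chloro group, but it keeps a substituent, chlorine, at the 2-position. A rise in this assay is therefore expected, though plausibly smaller than that seen from compound 1 to compound 2. The expected step is a 4.0-fold higher number from compound 3 to compound 4 (0.60 log units; beyond the scatter), and compound 4 is estimated at 1000 nM, within a range from 350 nM to 3000 nM.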

Compound 4, half-maximal inhibitory concentration: 4300 nM
Compound 4: the middle estimate sits 4.3-fold (0.63 log units) below what was measured; the measured number lies above the stated range.
By their numbers in this assay, from the lowest: compound 1; then compound 3; then compound 2; then compound 4.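

On the core of compound 3, putting 2,4-dichlorophenyl in place of 2-(trifluoromethoxy)phenyl on the aromatic nitrogen gives a 17-fold higher number from compound 3 to compound 4 (1.24 log units; beyond the scatter) in this assay and so weakens inhibition markedly even though the incoming aryl group keeps a substituent on the ring. This step is of much the same size as a 17-fold higher number from compound 1 to compound 2 (1.23 log units; beyond the scatter) on the core of compound 1, so both listed exchanges of an oxygen-bearing aryl group for a chlorine-bearing one go with a large rise, and neither pair goes against this. No measurement shown gives a reason for the rise at this position.

The compounds shown leave open whether the rise follows the loss of the oxygen-bearing group or the arrival of the chlorine atoms, since the two changes occur together in both steps. They also leave open how this position would respond to a plain phenyl group, or to an aryl group carrying an amine or a carboxylic acid, and whether the size of the step would hold on other cores.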